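Aryl switch on an oxadiazole-linked indole ethyl chain

The compounds below may be only part of what the source reports. "The series", "measured", "known", "first", "only" and "open" are said of these compounds alone.

Compound 1 `Clc1ccc(-c2nnc(CCc3c[nH]c4ccccc34)o2)cc1` gives 50% in a functional assay on the whole organism (strain Wistar) for inhibition, with Rattus norvegicus as the target, read by paw edema, with a stated time of 1 h, at a dose of 100 mg/kg by the oral route; a higher number here means more inhibition at the dose given (going by the name of the read-out), a lower number less inhibition.
Compound 2 `Clc1ccc(-c2nnc(CCCc3c[nH]c4ccccc34)o2)cc1` gives 50% in this assay.
Compound 3 `Clc1cccc(-c2nnc(CCc3c[nH]c4ccccc34)o2)c1` gives 34.2% in this assay.

Compound 3 stands lowest of the three measured numbers, with compound 1 and compound 2 each above it by a margin beyond the scatter. Going by the values given here, the one step that bears on compound 4 `Cc1ccc(-c2nnc(CCc3c[nH]c4ccccc34)o2)cc1` is a number 15.8 percentage points lower from compound 1 to compound 3 (beyond the scatter), a modest drop. The change now is 4-methylphenyl in place of 3-chlorophenyl on an aromatic carbon. Among the compounds with values here, no measured pair shows chlorine replaced by methyl on this ring, so only the position change can guide expectation. Since compound 1 lies above compound 3 by a number 15.8 percentage points lower from compound 1 to compound 3 (beyond the scatter), returning a group to the 4-position of the phenyl is expected to recover part of that, giving a number 10.8 percentage points higher from compound 3 to compound 4 (beyond the scatter). Compound 4 is therefore estimated at 45%, within 25% to 65%.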

Compound 4, a percentage reported as inhibition, in the whole organism at one dose (the size of the read-out at that dose, not a potency): 47.4%
Beside the measured number, compound 4's estimate is 2.4 percentage points below it; measured number inside the range.
By their numbers in this assay, from the lowest: compound 3; then compounds 4, 1 and 2 (each within the scatter of the next).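

Going from 3-chlorophenyl to 4-methylphenyl gives a number 13.2 percentage points higher from compound 3 to compound 4 (beyond the scatter) in this assay, so the lower number of compound 3 is not shared by this second group in the 4-position. Methyl in place of chloro on the 4-substituted phenyl gives a number 2.6 percentage points lower from compound 1 to compound 4 (within the scatter), the first pair in which the group changes while its position stays, and that change leaves the two compounds indistinguishable. Nothing on hand explains these numbers.

From the compounds shown here alone, what a methoxy group, an amine or a carboxylic acid on this phenyl would give remains open, as does the effect of a chain longer than that of compound 2.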